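The source may report more compounds than this note shows. Statements on the series, on what has been measured and on what is new or still open speak of the compounds shown alone.

Compound 3 `COc1ccc(-c2cc3ccccc3nc2/C=C/C(=O)c2ccc(OC)c(OC)c2)cc1` gives 3260 nM in a functional assay on SK-BR-3 cells (Homo sapiens) for antiproliferative activity, read by XTT assay, with a stated time of 72 h (a lower number here means a stronger inhibitor, a higher number a weaker inhibitor), the second highest of the three numbers: compound 2 `COc1ccc(-c2cc3ccccc3nc2/C=C/C(=O)c2ccc(O)cc2)cc1` gives 3880 nM, a 1.2-fold lower number from compound 2 to compound 3 (0.08 log units; within the scatter), while compound 1 `COc1ccc(-c2cc3ccccc3nc2/C=C/C(=O)c2ccccc2)cc1` gives 700 nM, a 4.7-fold higher number from compound 1 to compound 3 (0.67 log units; beyond the scatter). Compound 4 `COc1ccc(-c2cc3ccccc3nc2/C=C/C(=O)c2ccc[nH]2)cc1` differs from compound 3 by 1H-pyrrol-2-yl in place of 3,4-dimethoxyphenyl on a carbonyl carbon. Both measured steps alter the group on the carbonyl carbon: going from phenyl to a substituted phenyl was modest and beyond the scatter, whereas swapping one substituted phenyl for another stayed within it. Among the compounds with values here, no measured step introduces a five-membered ring, so the direction is uncertain. Since compound 1 with the plain phenyl gives the lowest number shown, a smaller ring on the carbonyl carbon is expected to move the number modestly downward, a 2.2-fold lower number from compound 3 to compound 4 (0.34 log units; beyond the scatter). Compound 4 is therefore estimated at 1500 nM, within 400 nM to 5500 nM.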

Compound 4, half-maximal inhibitory concentration: > 10000 nM
Compound 4 ended at the assay's limit; the forecaster's own chance of this, stated with the estimate: 5%; middle value at least 6.6-fold (0.82 log units) from the limit.
By their numbers in this assay, from the lowest: compound 1; then compounds 3 and 2 (each within the scatter of the next). At a limit, above all of these: compound 4.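

The value of compound 4 is a limit of the assay and not a number: the limit of > 10000 nM in this assay, at which 1 of the 4 values shown sits. With 1H-pyrrol-2-yl on the carbonyl carbon, the shift is an at least 3.0-fold higher number from compound 3 to compound 4 (0.48 log units; beyond the scatter), an at least 2.5-fold higher number from compound 2 to compound 4 (0.41 log units; beyond the scatter) and an at least 14-fold higher number from compound 1 to compound 4 (1.15 log units; beyond the scatter). Within the data shown here, the earlier compounds varied only six-membered aromatic rings of carbon at this place, so this is the first sign that a five-membered aromatic ring with a hetero atom carries the number past all three.

The compounds shown do not separate ring size from the ring nitrogen and its hydrogen. As far as these compounds go, how a furan or thiophene ring would read here stays open.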